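A few compounds are considered here, and "the series" means these few. Any claim that something is new, unique, unknown or untested is made for them only; others in the source may bear on it.

Compound 1 `CCCn1cnc2c(N)nc(NCc3ccccc3)nc21`: in a functional assay on CHO cells for antagonist activity at adenosine receptor A2b (Homo sapiens) (a lower number here means a stronger inhibitor, a higher number a weaker inhibitor), compound 1 gives > 30000 nM, which is a limit of the assay and not a number.
Compound 2 `CCCn1c(Br)nc2c(N)nc(NCc3ccccc3)nc21`: in this assay compound 2 gives 1740 nM.
Compound 3 `CCCn1cnc2c(NCc3ccccc3)ncnc21`: in this assay compound 3 gives > 30000 nM, again a limit of the assay.

Among the measured compounds shown here, only one single-point step connects these three compounds. It is bromo in place of hydrogen on an aromatic carbon, and it produces an at least 17-fold lower number from compound 1 to compound 2 (1.23 log units; beyond the scatter). Because two of the three values sit at the limit of > 30000 nM in this assay, at which 2 of the 3 values shown sit, this step is known only as a lower bound on its true size. Compound 1 and compound 3 differ in more than one place, and the difference between the two cores is not broken down here.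

Compound 4 `CCCn1c(Br)nc2c(NCc3ccccc3)ncnc21` has not yet been measured. It carries the same change on the core of compound 3, namely (bromo in place of hydrogen on an aromatic carbon), and the surroundings of the place read alike in both cases. For compound 4 the same kind of step is expected, an at least 3.7-fold lower number from compound 3 to compound 4 (0.57 log units; beyond the scatter), resting on the size of an at least 17-fold lower number from compound 1 to compound 2 (1.23 log units; beyond the scatter). Given that compound 3 starts at a limit, compound 4 is estimated to reach 8000 nM, with a plausible range from 1500 nM to 30000 nM.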

Compound 4, inhibition constant: 7490 nM
For compound 4 the middle estimate is 1.1-fold (0.03 log units) above the measured one; measured number inside the range.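

In this assay the replacement of hydrogen by bromo on the aromatic carbon gives an at least 4.0-fold lower number from compound 3 to compound 4 (0.60 log units; beyond the scatter), so the direction seen on the core of compound 1 also holds on the core of compound 3. Set side by side, the two steps are only lower bounds, and they do not show whether the change carries the same size from one core to the other: the same change on two cores in this assay, an at least 17-fold lower number (1.23 log units; beyond the scatter) from compound 1 to compound 2 and an at least 4.0-fold lower number (0.60 log units; beyond the scatter) from compound 3 to compound 4; the limit leaves it open whether they differ. On these data alone, the starting values of compound 1 and compound 3 are limits of the assay and not numbers, so the true size of the step on either core stays unknown: the limit of > 30000 nM in this assay, at which 2 of the 4 values shown sit.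

The compounds shown leave open whether chloro, iodo or an amine on the same aromatic carbon would lower the number as bromo does. They also leave open whether the step survives when the propyl group gives way to a longer chain, and whether it holds on any core beyond these two.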